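Naphthalenyl for methoxyphenyl on the hydrazone carbon: second instance

The compounds below may be only part of what the source reports. "The series", "measured", "known", "first", "only" and "open" are said of these compounds alone.

Working notes on a small set of fused thiazolone–oxindole hydrazones tested in a functional assay on cells (Cancer cell lines, Homo sapiens) for cytotoxicity, read by sulforhodamine B assay, with a stated time of 48 h; a lower number here means a stronger inhibitor of growth, a higher number a weaker inhibitor of growth.

Compound 1 `COc1ccc(C2=NN(C3=NC(=O)/C(=C4\C(=O)Nc5ccc(Br)cc54)S3)C(c3ccc(OC)cc3)C2)cc1` gives 25300 nM in this assay. Compound 2 `COc1ccc(C2CC(c3ccc4ccccc4c3)=NN2C2=NC(=O)/C(=C3\C(=O)Nc4ccc(Br)cc43)S2)cc1` gives 140 nM. The change between them is naphthalen-2-yl in place of 4-methoxyphenyl on a carbon with a double bond to nitrogen, and it made a step of a 180-fold lower number from compound 1 to compound 2 (2.26 log units; beyond the scatter).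

Compound 3 `COc1ccc(C2=NN(C3=NC(=O)/C(=C4\C(=O)Nc5ccccc54)S3)C(c3ccc(Cl)cc3)C2)cc1` gives 100000 nM, the highest number of the three measured compounds. The difference between the core of compound 3 and the core of compound 1 is not broken down here; the two values show compound 3 as a weaker inhibitor of growth than compound 1, and far weaker than compound 2.

Compound 4 `O=C1N=C(N2N=C(c3ccc4ccccc4c3)CC2c2ccc(Cl)cc2)S/C1=C1/C(=O)Nc2ccccc21` is not yet measured in this assay. It differs from compound 3 by naphthalen-2-yl in place of 4-methoxyphenyl on a carbon with a double bond to nitrogen. For the measured compounds named here, this is the same kind of change as the one from compound 1 to compound 2, though the surroundings are not identical: in compound 3 the ring atom two ring bonds away bears a 4-chlorophenyl group, whereas in compound 1 it bears a 4-methoxyphenyl group.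

The expectation for compound 4 rests on a single precedent, the step of a 180-fold lower number from compound 1 to compound 2 (2.26 log units; beyond the scatter), and on the starting point of compound 3, which gives 100000 nM. Because compound 3 gives 100000 nM and the precedent stands on one pair only, the expected step from compound 3 to compound 4 is taken as a 130-fold lower number from compound 3 to compound 4 (2.10 log units; beyond the scatter), somewhat smaller than the precedent. Compound 4 is therefore estimated at 800 nM, with a plausible range from 150 nM to 5000 nM.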

Compound 4, concentration for total growth inhibition: 70300 nM
Estimate against measurement, compound 4: 88-fold (1.94 log units) below; measured number above the stated range.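

In this assay, naphthalen-2-yl in place of 4-methoxyphenyl on the carbon with a double bond to nitrogen gives a 1.4-fold lower number from compound 3 to compound 4 (0.15 log units; within the scatter), so on this second core the change brings no difference beyond the scatter. The change therefore does not carry over as a fixed step from one core to the other: the same change on two cores in this assay, a 180-fold lower number (2.26 log units; beyond the scatter) from compound 1 to compound 2 and a 1.4-fold lower number (0.15 log units; within the scatter) from compound 3 to compound 4, 130-fold (2.10 log units) apart, beyond the scatter of two such steps What this does not show is which feature of the cores sets the size of the step: the core of compound 1 and the core of compound 3 differ in more than one place, and two pairs give no rule for any further core in the series.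

Going by these compounds, it remains open whether the large step depends on the 4-methoxyphenyl group or the 4-chlorophenyl group on the ring, or on another part of the core, a question that only pairs differing in one of these places at a time could settle. Also open, on these data alone, is what a pyridinyl ring, an amine or a carboxylic acid on the carbon with a double bond to nitrogen would give on either core.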